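Para-substituent swap on the benzoyl ring of compound 1

This account rests on a few compounds, and the source may have more. Where it says the series, first, only, none or still open, it means among the compounds named here.

Measured so far:
compound 1 `O=C(/C(=C\c1ccc(O)c([N+](=O)[O-])c1)SCc1ccc(Br)cc1)c1ccc(C(F)(F)F)cc1` — 10000 nM
compound 2 `O=C(/C(=C\c1ccc([N+](=O)[O-])c(O)c1)SCc1ccc(Br)cc1)c1ccc(C(F)(F)F)cc1` — 1000 nM

In a functional assay on DU-145 cells (Homo sapiens) for inhibition, read by trypan blue exclusion, with a stated time of 96 h (on this read-out lower numbers stand for stronger inhibition of growth and higher numbers for weaker inhibition of growth), compound 1 stands highest of the two numbers; its nearest neighbour is compound 2, separated by a 10-fold lower number from compound 1 to compound 2 (1.00 log units; beyond the scatter). Compound 3 `O=C(/C(=C\c1ccc(O)c([N+](=O)[O-])c1)SCc1ccc(Br)cc1)c1ccc(Br)cc1` differs from compound 1 by bromo in place of trifluoromethyl on an aromatic carbon. Among the compounds with values here, no measured step touches this position: the only step available concerns the hydroxy/nitro ring, not the benzoyl ring, and the second step of this kind is absent. With no bearing data, the expectation for compound 3 in this assay is no change at the digits printed from compound 1 to compound 3 (within the scatter), that is, nothing beyond the scatter. Compound 3 is therefore estimated at 10000 nM, within 3000 nM to 30000 nM.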

Compound 3, concentration for 50% growth inhibition: 10000 nM
Beside the measured number, compound 3's estimate shows no gap at the digits printed, within the range that was stated.
By their numbers in this assay, from the lowest: compound 2; then compounds 1 and 3 (each within the scatter of the next).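

Within the data shown here, exchanging 4-(trifluoromethyl)phenyl for 4-bromophenyl is the only measured change at this position, and in this assay it shows no change at the digits printed from compound 1 to compound 3 (within the scatter). On the 4-hydroxy-3-nitrophenyl background of compound 1, bromo thus serves in place of trifluoromethyl without a step beyond the scatter. No available evidence bears on this result.

Going by these compounds, whether the same exchange holds with the 3-hydroxy-4-nitrophenyl arrangement of compound 2 remains open. So does the effect of a different kind of group at this position, such as an amine or a carboxylic acid.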